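A few compounds are considered here, and "the series" means these few. Any claim that something is new, unique, unknown or untested is made for them only; others in the source may bear on it.

Compound 2 `CC(C)=CC(=O)Nc1cccc(Oc2nc(Nc3cccc(C#N)c3)nc3ccsc23)c1` is the weaker of the two inhibitors measured here: in a functional assay on MCF7 cells (Homo sapiens) for inhibition, read by MTT assay, with a stated time of 72 h (on this read-out higher numbers stand for weaker inhibition and lower numbers for stronger inhibition), compound 2 gives 41100 nM, the highest of the two numbers. Its nearest neighbour is compound 1 `C=CC(=O)Nc1cccc(Oc2nc(Nc3cccc(C#N)c3)nc3ccsc23)c1`, which in this assay gives 19000 nM. Within the data shown here, the one step available, a 2.2-fold higher number from compound 1 to compound 2 (0.34 log units; beyond the scatter), shows that replacing vinyl with 2-methylprop-1-en-1-yl on the carbonyl carbon weakened inhibition modestly. Compound 3 `CC/C=C/C(=O)Nc1cccc(Oc2nc(Nc3cccc(C#N)c3)nc3ccsc23)c1` is built from the same atoms as compound 2, joined differently: but-1-en-1-yl in place of 2-methylprop-1-en-1-yl on a carbonyl carbon. Among the measured compounds shown here, no measured step covers this rearrangement directly; the only comparison at hand is the step from vinyl to the dimethyl-substituted alkene, and compound 3 keeps a substituted alkene on the carbonyl carbon, now as a straight but-1-en-1-yl chain. Compound 3 is therefore expected to land close to compound 2, possibly drifting back toward compound 1, so the expected step of a 1.4-fold lower number from compound 2 to compound 3 (0.14 log units; within the scatter) is small and within the scatter. The estimate for compound 3 in this assay is 30000 nM, with a range from 12000 nM to 80000 nM.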

Compound 3, half-maximal inhibitory concentration: > 50000 nM
Compound 3: a limit, no number (the forecaster's own chance of this, stated with the estimate: 10%); middle value at least 1.6-fold (0.22 log units) from the limit.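

For compound 3 the read-out in this assay is a limit and not a number: the limit of > 50000 nM in this assay, at which 1 of the 3 values shown sits. The step from vinyl now has a second substituent behind it, since but-1-en-1-yl in place of vinyl on the carbonyl carbon gives an at least 2.6-fold higher number from compound 1 to compound 3 (0.42 log units; beyond the scatter), so among these three compounds both groups of four carbons on the carbonyl carbon, the branched 2-methylprop-1-en-1-yl and the straight but-1-en-1-yl, weaken inhibition relative to vinyl, and none of the three goes against this. The rearrangement of the same atoms gives an at least 1.2-fold higher number from compound 2 to compound 3 (0.08 log units; that floor lies within the scatter), and as that floor lies within the scatter, the limit does not separate the straight chain from the branched one, so this position is shown to disfavour both groups without ranking them.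

As far as these compounds go, how far compound 3 lies past its limit stays open, and with it any true order of the two isomeric groups. Also open, from the compounds shown here alone, is whether a chain on the carbonyl carbon that carries an amine, such as a dimethylamino group at the end of the but-1-en-1-yl chain, or a saturated ethyl group in place of vinyl, would keep, weaken or strengthen inhibition in this assay.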